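Hydrazone series: methoxy in place of fluoro on the aryl ring

A few compounds are considered here, and "the series" means these few. Any claim that something is new, unique, unknown or untested is made for them only; others in the source may bear on it.

Measured so far in a functional assay on the whole organism (strain Wistar) for inhibition, with Rattus norvegicus as the target, read by paw edema, with a stated time of 4 h, at a dose of 10 mg/kg by the intraperitoneal route; on this read-out lower numbers stand for less inhibition and higher numbers for more inhibition at the one dose given (going by the name of the read-out):
compound 1 `O=C(N/N=C/c1ccccc1)c1cccnc1Nc1cccc(C(F)(F)F)c1` — 31%
compound 2 `O=C(N/N=C/c1ccc(F)cc1)c1cccnc1Nc1cccc(C(F)(F)F)c1` — 36.5%
compound 3 `O=C(N/N=C/c1ccc(Cl)cc1)c1cccnc1Nc1cccc(C(F)(F)F)c1` — 43.7%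

Compound 2 holds the second highest of the three numbers in this assay. Its nearest neighbour is compound 1, a number 5.5 percentage points higher from compound 1 to compound 2 (within the scatter), and its furthest is compound 3, a number 7.2 percentage points higher from compound 2 to compound 3 (within the scatter); neither gap reaches beyond the scatter, so the three compounds cannot be ordered on these data alone. Only a number 12.7 percentage points higher from compound 1 to compound 3 (beyond the scatter) stands out.

The next compound is compound 4 `COc1cccc(/C=N/NC(=O)c2cccnc2Nc2cccc(C(F)(F)F)c2)c1`, which differs from compound 2 as follows: 3-methoxyphenyl in place of 4-fluorophenyl on a carbon with a double bond to nitrogen.

The three measured steps all concern a hydrogen, fluoro or chloro at one position of this ring; none of them involves a methoxy group, and none moves the substituent to another position. The steps within the scatter, from compound 1 to compound 2 and from compound 2 to compound 3, show that small changes on this ring have so far left the read-out largely unmoved; the step from compound 1 to compound 3 was modest. Within the data shown here, no measured step therefore bears directly on the change to compound 4, and the expectation is no step beyond the scatter, a number 0.5 percentage points lower from compound 2 to compound 4 (within the scatter). Compound 4 is estimated at 36%, between 26% and 47%.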

Compound 4, a percentage reported as inhibition, in the whole organism at one dose (the size of the read-out at that dose, not a potency): 14.9%
Beside the measured number, compound 4's estimate is 21.1 percentage points above it; measured number outside the range, below it.
By their numbers in this assay, from the lowest: compound 4; then compounds 1, 2 and 3 (each within the scatter of the next, the first and the last beyond it).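

In this assay, the aryl group on the carbon with a double bond to nitrogen can move the read-out well past the scatter: 3-methoxyphenyl gives a number 21.6 percentage points lower from compound 2 to compound 4 (beyond the scatter), a number 28.8 percentage points lower from compound 3 to compound 4 (beyond the scatter) and a number 16.1 percentage points lower from compound 1 to compound 4 (beyond the scatter). Among these compounds, compound 4 is the only one of the four whose steps to all the others lie beyond the scatter, and it holds the lowest number, whereas the only earlier step beyond the scatter, a number 12.7 percentage points higher from compound 1 to compound 3 (beyond the scatter), ran in the opposite direction. Nothing measured here speaks to why the number falls.

The step from the halogen compounds changes the substituent and its place on the ring together, so these compounds do not show whether the methoxy group itself or its place carries the drop. Also open, from the compounds shown here alone, is how an amine, a carboxylic acid or a longer alkoxy chain such as butoxy on this ring would read in this assay, and whether any such group would stay with compound 4 or with compound 3.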